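This account rests on a few compounds, and the source may have more. Where it says the series, first, only, none or still open, it means among the compounds named here.

Compound 1 `CC(C)OC(=O)N1CCC(CCCC(=O)c2ncco2)CC1`: 4 nM
Compound 2 `Cc1cccc(CN2CCC(CCCC(=O)c3ncco3)CC2)c1`: 90 nM

Both compounds were tested in an assay on isolated protein for inhibition of Fatty-acid amide hydrolase 1 (Homo sapiens); a lower number here means a stronger inhibitor, a higher number a weaker inhibitor. Among the compounds with values here, of the two numbers in this assay, compound 2 gives the highest, and the only step measured so far, a 23-fold higher number from compound 1 to compound 2 (1.35 log units; beyond the scatter), lies well beyond the scatter; it exchanged the carbamate group on the ring amine nitrogen for a benzyl group.

Compound 3 `O=C(CCCC1CCN(Cc2ccccc2Cl)CC1)c1ncco1` differs from compound 2 in one place: 2-chlorophenyl in place of 3-methylphenyl on a saturated chain carbon bound to an amine nitrogen in a ring. Within the data shown here, the single measured step concerns the replacement of the whole group on the ring amine nitrogen, not a change within the aromatic ring of the benzyl group, so no measured step bears directly on this change. Among the measured compounds shown here, with no precedent of that kind in the data, a step within the usual scatter is expected from compound 2 to compound 3, that is a 1.1-fold lower number from compound 2 to compound 3 (0.05 log units; within the scatter). Compound 3 is therefore estimated at 80 nM, with an expected range from 25 nM to 250 nM.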

Compound 3, half-maximal inhibitory concentration: 260 nM
Estimate against measurement, compound 3: 3.3-fold (0.51 log units) below; measured number above the stated range.
By their numbers in this assay, from the lowest: compound 1; then compound 2; then compound 3.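

The aromatic ring of the benzyl group matters as well: in this assay, 2-chlorophenyl in place of 3-methylphenyl gives a 2.9-fold higher number from compound 2 to compound 3 (0.46 log units; beyond the scatter), a modest step but beyond the scatter. Within the data shown here, until now, the only measured change at this position replaced the whole group on the ring amine nitrogen, whereas this one keeps the benzyl group and the count of heavy atoms, and the distance from the carbamate now reads a 65-fold higher number from compound 1 to compound 3 (1.81 log units; beyond the scatter). Nothing available bears on the cause of the new step.

This step changes both the substituent and its place on the ring, so the two cannot be told apart. A 3-chlorobenzyl or a 2-methylbenzyl group would separate them, and a plain benzyl group would show how either substituent compares with none.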